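This account rests on a few compounds, and the source may have more. Where it says the series, first, only, none or still open, it means among the compounds named here.

Measured so far in a toxicity assay on THP-1 cells (Homo sapiens) for inhibition; on this read-out lower numbers stand for higher toxicity in this test and higher numbers for lower toxicity in this test:
- compound 1 `Cc1ccccc1-c1cnc(NC(=O)c2ccc(F)cc2)n1C`: > 50000 nM
- compound 2 `Cn1c(-c2ccc(F)cc2)cnc1NC(=O)c1ccc(F)cc1`: > 100000 nM

Both entries are limits of the assay, not numbers.

Compound 2 stands only at a limit, > 100000 nM. Compound 3 `Cc1cccc(-c2cnc(NC(=O)c3ccc(F)cc3)n2C)c1` carries 3-methylphenyl in place of 4-fluorophenyl on an aromatic carbon. Among the compounds with values here, the one measured step that bears on this change is a step that the two limits leave unreadable from compound 1 to compound 2. It gives no size to carry over. Compound 1 is likewise known only as a limit, > 50000 nM. No step beyond the scatter is therefore expected in this assay, and no direction can be assigned. The estimated step is an at least 1.2-fold lower number from compound 2 to compound 3 (0.09 log units; that floor lies within the scatter). A report of compound 3 as a limit is also expected. For compound 3 the expected value is 80000 nM, with an estimated range of 30000 nM to 200000 nM.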

Compound 3, half-maximal cytotoxic concentration: > 100000 nM
Compound 3 gave a limit, no number; the forecaster's own chance of this, stated with the estimate: 80%; middle value at least 1.2-fold (0.09 log units) from the limit.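

In this assay all three values are limits of the assay and not numbers, so no step can be read among compound 1, compound 2 and compound 3. The compounds shown leave open how 2-methylphenyl, 3-methylphenyl and 4-fluorophenyl compare in this assay.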